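A few compounds are considered here, and "the series" means these few. Any claim that something is new, unique, unknown or untested is made for them only; others in the source may bear on it.

The set rests on a shared core and comprises two measured compounds, compound 1 `C=CCn1c(=O)/c(=C\c2cc(Br)ccc2F)[nH]c(=O)/c1=C\c1ccccc1OC` and compound 2 `C=CCn1c(=O)/c(=C\c2cccc(Br)c2)[nH]c(=O)/c1=C\c1ccccc1OC`. In a functional assay on BGC-823 cells (Homo sapiens) for cytotoxicity, read by CCK-8 assay, with a stated time of 72 h (on this read-out higher numbers stand for weaker inhibition and lower numbers for stronger inhibition), compound 1 was reported as "not active" (no number reported), so no number stands against it. In this assay, among the measured compounds shown here, compound 2 gives 5900 nM, which is the only number reported in the whole set, with compound 1 being the further entry without one. A third member, compound 3 `C=CCn1c(=O)/c(=C\c2ccccc2C(F)(F)F)[nH]c(=O)/c1=C\c1ccccc1OC`, has not yet been measured in this assay. Its structure differs from that of compound 2 in a single place: 2-(trifluoromethyl)phenyl in place of 3-bromophenyl on a double-bonded chain carbon bound to an aromatic carbon. For the measured compounds named here, no step between two measured compounds is available, so the size of this change cannot be read from a measured pair. Compound 2 at 5900 nM is the sole anchor, and compound 1 gave no number at all. On that basis the step is expected to run toward weaker inhibition, possibly beyond the usual scatter, estimated as a 2.0-fold higher number from compound 2 to compound 3 (0.31 log units; beyond the scatter). Compound 3 is therefore expected to give about 12000 nM in this assay, within an estimated range from 4000 nM to 40000 nM, with a real chance that only a limit is reported.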

Compound 3, half-maximal inhibitory concentration: 5100 nM
The estimate for compound 3 lay 2.4-fold (0.37 log units) above the measured number; low and high end bracket the measured number.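

In this assay, the first step measured at this position, 2-(trifluoromethyl)phenyl in place of 3-bromophenyl on a double-bonded chain carbon bound to an aromatic carbon, gives a 1.2-fold lower number from compound 2 to compound 3 (0.06 log units; within the scatter), so the exchange of one group for the other leaves the read-out unchanged within the scatter. Among the compounds shown here, compound 3 thus shows that a second aryl group at this place can return a number, whereas compound 1, with its own aryl group there, gives "not active" (no number reported), and no step to or from compound 1 can be read. No measured information on the compounds accounts for this similarity between compound 2 and compound 3.

Going by these compounds, the pair changes both the group carried on the phenyl ring and its location at once, so it remains open whether either change alone would leave the number in the same range. Also open, on these data alone, is how this place responds to an amine or a carboxylic acid on the phenyl ring, and how changes elsewhere on the shared core would read.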